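Swapping the carbamoyl of compound 3 for 3-fluorophenyl

A few compounds are considered here, and "the series" means these few. Any claim that something is new, unique, unknown or untested is made for them only; others in the source may bear on it.

Values in a functional assay on a cell-free system (plasma, Oryctolagus cuniculus) for inhibition, with stated times of 5 min, 1 min and 6 min; on this read-out lower numbers stand for stronger inhibition and higher numbers for weaker inhibition:
- compound 1 `CCOC(=O)c1c(C)nc(-c2cccc(C#N)c2)n1O`: 17600 nM
- compound 2 `CCOC(=O)c1c(C)nc(-c2cccc(C#N)c2)n1OCCCO`: 11400 nM
- compound 3 `CCOC(=O)c1c(C)nc(-c2cccc(C#N)c2)n1OCC(N)=O`: > 30000 nM (a limit, not a number)

Only a limit is known for compound 3 (the limit of > 30000 nM in this assay, at which 1 of the 3 values shown sits). Compound 4 `CCOC(=O)c1c(C)nc(-c2cccc(C#N)c2)n1OCc1cccc(F)c1` carries 3-fluorophenyl in place of carbamoyl on a saturated chain carbon bound to an oxygen on an aromatic ring. For the measured compounds named here, three measured steps bear on this change. The step of a 1.5-fold lower number from compound 1 to compound 2 (0.19 log units; within the scatter) shows 3-hydroxypropyl on that oxygen. The step of an at least 1.7-fold higher number from compound 1 to compound 3 (0.23 log units; that floor lies within the scatter) shows carbamoylmethyl there. The clearest is an at least 2.6-fold higher number from compound 2 to compound 3 (0.42 log units; beyond the scatter) and it is the one that removes the hydroxyl chain in favour of carbamoyl. Going by the values given here, no measured compound has an aromatic group on that oxygen, so the expectation stays broad. In this assay a lower number is expected, estimated as an at least 2.5-fold lower number from compound 3 to compound 4 (0.39 log units; beyond the scatter) for this swap. For compound 4 the expected value is 12000 nM with an estimated range from 4000 nM to 30000 nM as a guide.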

Compound 4, half-maximal inhibitory concentration: 22400 nM
For compound 4 the middle estimate is 1.9-fold (0.27 log units) below the measured one; the measured number falls inside the stated range.
By their numbers in this assay, from the lowest: compounds 2, 1 and 4 (each within the scatter of the next). At a limit, above all of these: compound 3.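

In this assay, an aromatic ring on this oxygen now has a reading, and 3-fluorobenzyl in place of hydrogen gives a 1.3-fold higher number from compound 1 to compound 4 (0.10 log units; within the scatter). Set against the hydroxyl chain, the change gives a 2.0-fold higher number from compound 2 to compound 4 (0.29 log units; within the scatter), so this larger group leaves the number level with those of the two earlier compounds. The swap for carbamoyl gives an at least 1.3-fold lower number from compound 3 to compound 4 (0.12 log units; that floor lies within the scatter), and compound 3 stays a limit: the limit of > 30000 nM in this assay, at which 1 of the 4 values shown sits.

Open, from the compounds shown here alone, is whether an unsubstituted benzyl, an amine or a carboxylic acid on that oxygen would move the number beyond the scatter. Also open, going by these compounds, is whether any group there reaches much lower numbers.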